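From 2-fluorophenyl to 4-bromophenyl on compound 3

This account rests on a few compounds, and the source may have more. Where it says the series, first, only, none or still open, it means among the compounds named here.

Measured in a functional assay on THP-1 cells (Homo sapiens) for cytotoxicity, read by MTT assay, with a stated time of 24 h (a higher number here means a weaker inhibitor, a lower number a stronger inhibitor), so far:
Compound 1 `COc1ccc(/C=C2\CN(C)C/C(=C\c3ccccc3F)C2=O)cc1OC` gives 11200 nM
Compound 2 `COc1cc(/C=C2\CN(C)C/C(=C\c3ccccc3F)C2=O)cc(OC)c1` gives 1170 nM
Compound 3 `COc1cc(/C=C2\CN(C)C/C(=C\c3ccccc3F)C2=O)cc(OC)c1OC` gives 640 nM

Compound 3 shares the low end of these numbers with compound 2. The step there is a 1.8-fold lower number from compound 2 to compound 3 (0.26 log units; within the scatter) and gives no order between the two. The other measured step is far larger, at an 18-fold lower number from compound 1 to compound 3 (1.24 log units; beyond the scatter) and it sets the remaining compound apart.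

Going on to compound 4 `COc1cc(/C=C2\CN(C)C/C(=C\c3ccc(Br)cc3)C2=O)cc(OC)c1OC` brings 4-bromophenyl in place of 2-fluorophenyl on a double-bonded chain carbon bound to a double-bonded ring carbon and this is 4-bromophenyl in place of 2-fluorophenyl on a double-bonded chain carbon bound to a double-bonded ring carbon. Neither measured step touches that place. Going by the values given here, both put methoxy in place of hydrogen on an aromatic carbon, so the data hold no direct precedent for this swap. They show only that a single substitution here can leave the number within the scatter or move it well beyond.

With compound 3 at 640 nM as the only anchor, no step beyond the scatter is expected in this assay and no direction is favoured. Compound 4 is estimated at 650 nM with an expected range from 200 nM to 2200 nM given the missing precedent. This would be an expected 1.0-fold higher number from compound 3 to compound 4 (0.01 log units; within the scatter) and it remains an estimate until measured.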

Compound 4, half-maximal inhibitory concentration: 5330 nM
For compound 4 the middle estimate is 8.2-fold (0.91 log units) below the measured one, and the stated range ends below it.
By their numbers in this assay, from the lowest: compounds 3 and 2 (each within the scatter of the next); then compound 4; then compound 1.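

In this assay this place on the shared core proves sensitive: 4-bromophenyl in place of 2-fluorophenyl on a double-bonded chain carbon bound to a double-bonded ring carbon gives an 8.3-fold higher number from compound 3 to compound 4 (0.92 log units; beyond the scatter) and so moves the number beyond the scatter. The earlier steps shown here showed such a move only for methoxy in place of hydrogen on an aromatic carbon, whereas this one shows that the aromatic group at the other place matters as well, even though the two groups have the same heavy-atom count, the same hydrogen-bond donor and acceptor counts, and no net charge. No measurement at hand accounts for the size or direction of this step.

The step exchanges both the halogen and where it sits on the phenyl, and the compounds shown do not separate those two changes. Also open, from the compounds shown here alone, is whether the methoxy steps seen with 2-fluorophenyl hold with 4-bromophenyl, and how the number would respond to a phenyl carrying an amine or a carboxylic acid at this place.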